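The source may report more compounds than this note shows. Statements on the series, on what has been measured and on what is new or still open speak of the compounds shown alone.

Measured so far:
- Compound 1 `CN1CC(C)(CO)Oc2cc(N(Cc3ccccc3)C(=O)C(=O)O)ccc21`: > 100000 nM, a limit of the assay
- Compound 2 `CCOC(=O)CN(Cc1cccc(F)c1)c1ccc2c(c1)N(C)CC(C)(COc1ccc(C(=N)N)cc1)O2`: 4600 nM

In a functional assay on HeLa cells (Homo sapiens) for antiproliferative activity, read by cell counting, with a stated time of 4 days (a higher number here means a weaker inhibitor, a lower number a stronger inhibitor), compound 1 gives no number, only the limit > 100000 nM. Compound 1 therefore stands at the limit of > 100000 nM in this assay, at which 1 of the 2 values shown sits. Compound 2 reads 4600 nM, a measured number.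

Compound 3 `CN1CC(C)(CO)Oc2cc(N(Cc3cc(F)cc(F)c3)C(=O)C(=O)O)ccc21` departs from compound 1 in one place: 3,5-difluorophenyl in place of phenyl on a saturated chain carbon bound to an amide-type nitrogen. Cut one bond further out, this reads benzyl to 3,5-difluorobenzyl. For the measured compounds named here, no step between measured compounds gauges such a change, so no shift beyond the scatter is expected in this assay, in either direction. The expectation rests on compound 1, whose only reading is the limit > 100000 nM. The estimate is a number no higher from compound 1 to compound 3 (the limit leaves the size open), and the assay may well report a limit again. Compound 3 is expected at 100000 nM, with an estimated range of 40000 nM to 250000 nM.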

Compound 3, half-maximal inhibitory concentration: > 100000 nM
Compound 3: only a limit was reported (the forecaster's own chance of this, stated with the estimate: 80%); the middle value lies on the limit itself.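

Compound 1 and compound 3 both give only a limit in this assay, so no step can be read between them: the limit of > 100000 nM in this assay, at which 2 of the 3 values shown sit. As far as these compounds go, whether 3,5-difluorophenyl in place of phenyl changes the antiproliferative activity in this assay stays open.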